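Sulfonyl aryl swap on a quinoline core, second instance

The compounds below may be only part of what the source reports. "The series", "measured", "known", "first", "only" and "open" are said of these compounds alone.

Measured compounds:
compound 1 `CC1CCN(c2c(S(=O)(=O)c3cc(Cl)cc(Cl)c3)cnc3ccc(Cl)cc23)CC1`, 88%
compound 2 `CC1CCN(c2c(S(=O)(=O)c3cccc(F)c3)cnc3ccc(Cl)cc23)CC1`, 58%
compound 3 `COc1ccc2ncc(S(=O)(=O)c3cc(Cl)cc(Cl)c3)c(N3CCC(C)CC3)c2c1`, 87%

All three were tested in an assay on isolated protein for displacement of a labelled ligand from metabotropic glutamate receptor 5 (Homo sapiens), with a stated time of 60 min, tested at 1 uM; a higher number here means more inhibition at the concentration tested (going by the name of the read-out), a lower number less inhibition. Compound 1 gives 88%, compound 2 gives 58% and compound 3 gives 87%. The change from compound 1 to compound 2 is 3-fluorophenyl in place of 3,5-dichlorophenyl on a sulfonyl sulfur, and it brought a number 30 percentage points lower from compound 1 to compound 2 (beyond the scatter). Compound 3 differs from compound 1 by methoxy in place of chloro on an aromatic carbon, with a number 1 percentage points lower from compound 1 to compound 3 (within the scatter), so the two cores behave alike in this assay.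

Compound 4 `COc1ccc2ncc(S(=O)(=O)c3cccc(F)c3)c(N3CCC(C)CC3)c2c1` is not yet measured. It differs from compound 3 by 3-fluorophenyl in place of 3,5-dichlorophenyl on a sulfonyl sulfur, the same change as that from compound 1 to compound 2, made at a place described in identical words. Since that change produced a number 30 percentage points lower from compound 1 to compound 2 (beyond the scatter) on a core that behaves like the core of compound 3, a similar step, a number 30 percentage points lower from compound 3 to compound 4 (beyond the scatter), is expected here. Compound 4 is therefore estimated at 57%, with a likely span from 40% to 72%.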

Compound 4, a percentage reported as inhibition, at one concentration (the size of the read-out at that concentration, not a potency): 68%
Compound 4: the middle estimate sits 11 percentage points below what was measured; the range from low to high includes it.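

In this assay, 3-fluorophenyl in place of 3,5-dichlorophenyl on the core of compound 3 gave a number 19 percentage points lower from compound 3 to compound 4 (beyond the scatter), the same direction as on the core of compound 1, and the two steps do not separate: the same change on two cores in this assay, a number 30 percentage points lower (beyond the scatter) from compound 1 to compound 2 and a number 19 percentage points lower (beyond the scatter) from compound 3 to compound 4, 11 percentage points apart, within the scatter of two such steps. Methoxy in place of chloro, read among the 3-fluorophenyl compounds, gave a number 10 percentage points higher from compound 2 to compound 4 (within the scatter), and this step also agrees with its earlier counterpart: the same change on two cores in this assay, a number 1 percentage points lower (within the scatter) from compound 1 to compound 3 and a number 10 percentage points higher (within the scatter) from compound 2 to compound 4, 11 percentage points apart, within the scatter of two such steps. This shows that the sulfonyl aryl change carried across these two cores at a single tested concentration, but it does not show that it would carry to any other core, and it gives no potency.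

The compounds shown leave open how a pyridyl group or a trifluoromethylphenyl group on the sulfonyl sulfur would compare. They also leave open whether the steps would hold with a nitrile on that aromatic carbon.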